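Working notes: sulfamoyl in place of hydrogen on compound 3

This account rests on a few compounds, and the source may have more. Where it says the series, first, only, none or still open, it means among the compounds named here.

Measured so far in an ADME assay on MT4 cells (Homo sapiens) for cytotoxicity, read by MTT assay (a lower number here means that less compound is tolerated, a higher number that more compound is tolerated), as follows:
- compound 1 `Cc1ccc(NC(=O)CSc2nncnc2-c2cccc3ccccc23)c(Br)c1` gives 166000 nM
- compound 2 `COC(=O)c1ccc(NC(=O)CSc2nncnc2-c2cccc3ccccc23)c(Br)c1` gives 173000 nM
- compound 3 `O=C(CSc1nncnc1-c1cccc2ccccc12)Nc1ccccc1Br` gives 87000 nM

Compound 3 stands within the scatter of the other two, as a 1.9-fold lower number from compound 1 to compound 3 (0.28 log units; within the scatter) and a 2.0-fold lower number from compound 2 to compound 3 (0.30 log units; within the scatter) show. The change to compound 4 `NS(=O)(=O)c1ccc(NC(=O)CSc2nncnc2-c2cccc3ccccc23)c(Br)c1` is sulfamoyl in place of hydrogen on an aromatic carbon and puts sulfamoyl in place of hydrogen on an aromatic carbon, meta to a bromo group and para to a large group. Those two steps bear on it: each exchanges hydrogen with another group on an aromatic carbon, and neither goes beyond the scatter. Sulfamoyl itself is untested here. In this assay a small rise, with no step beyond the scatter, is therefore expected. The expected step is a 1.6-fold higher number from compound 3 to compound 4 (0.21 log units; within the scatter) as estimated. For compound 4 the estimate is 140000 nM within a range of 65000 nM to 280000 nM as expected bounds.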

Compound 4, half-maximal cytotoxic concentration: 23000 nM
Compound 4: middle estimate off by 6.1-fold (0.78 log units), on the high side; measured number outside the range, below it.
By their numbers in this assay, from the lowest: compound 4; then compounds 3, 1 and 2 (each within the scatter of the next).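

In this assay, this place, para to a large group, gives its first step beyond the scatter with sulfamoyl (a 3.8-fold lower number from compound 3 to compound 4 (0.58 log units; beyond the scatter)), whereas methyl and methoxycarbonyl stayed within the scatter of each other and of hydrogen. Sulfamoyl also separates from both of those groups (a 7.2-fold lower number from compound 1 to compound 4 (0.86 log units; beyond the scatter); a 7.5-fold lower number from compound 2 to compound 4 (0.88 log units; beyond the scatter)), so the place is not indifferent to what it carries. No measurement at hand accounts for this result. On these data alone, whether methylsulfonyl or a carboxylic acid at this place would track compound 4 or compound 2 stays open.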